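This account rests on a few compounds, and the source may have more. Where it says the series, first, only, none or still open, it means among the compounds named here.

Measured so far in a physicochemical assay for solubility, measured as kinetic solubility; a higher number here means a more soluble compound, a lower number a less soluble compound:
- compound 1 `Cc1cnc(NC(=O)c2cc(Oc3cnc(C(=O)N(C)C)cn3)c3cc(C)oc3c2)cn1` gives 176000 nM 
- compound 2 `Cc1cnc(NC(=O)c2cc(Oc3cnc(C(=O)N4CCCC4)cn3)c3cc(C)oc3c2)cn1` gives 4500 nM 

Compound 1 holds the higher of the two numbers. Going by the values given here, the only measured step is a 39-fold lower number from compound 1 to compound 2 (1.59 log units; beyond the scatter) with pyrrolidin-1-yl in place of dimethylamino on a carbonyl carbon.

Compound 3 `Cc1ccc(NC(=O)c2cc(Oc3cnc(C(=O)N(C)C)cn3)c3cc(C)oc3c2)nc1` is not yet measured. It differs from compound 1 in one place, on an amide-type nitrogen, with 5-methylpyridin-2-yl in place of 5-methylpyrazin-2-yl (5-methylpyridin-2-yl in place of 5-methylpyrazin-2-yl on an amide-type nitrogen). Among the compounds with values here, the one measured step lies at a different place, so no measured step covers this change directly. Within the data shown here, it shows only that a single change can move the number far. With compound 1 at 176000 nM as the highest number seen so far, a lower number is the more likely direction, though the data do not settle this. A moderate move is expected, namely a 2.5-fold lower number from compound 1 to compound 3 (0.40 log units; beyond the scatter) in this assay as a loose working figure. The estimated value for compound 3 is 70000 nM with an expected range of 15000 nM to 200000 nM for now.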

Compound 3, solubility: 215000 nM
Compound 3: middle estimate off by 3.1-fold (0.49 log units), on the low side; measured number above the stated range.
By their numbers in this assay, from the lowest: compound 2; then compounds 1 and 3 (each within the scatter of the next).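

In this assay, replacing 5-methylpyrazin-2-yl with 5-methylpyridin-2-yl on the amide-type nitrogen gives a 1.2-fold higher number from compound 1 to compound 3 (0.09 log units; within the scatter), so this position accepts a change from 2 hydrogen-bond acceptors to 1 in the group, with the same number of heavy atoms, without a step beyond the scatter. Going by these compounds alone, the only other measured step, at the carbonyl carbon, is a 39-fold lower number from compound 1 to compound 2 (1.59 log units; beyond the scatter), which shows that the large move seen so far does not carry over to every single change, and that this aromatic ring swap on the amide-type nitrogen is not one of the changes that moves the number far. No measured evidence bears on the reason for this result.

The compounds shown leave open whether 5-methylpyridin-2-yl on the amide-type nitrogen would give a similar reading with pyrrolidin-1-yl in place of dimethylamino on the carbonyl carbon. They also leave open how far the reading would hold on this nitrogen with a plain phenyl ring, or with a ring carrying a carboxylic acid or an amine in place of the methyl group.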